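Mirror-image change at the chain carbon of compound 3

The source may report more compounds than this note shows. Statements on the series, on what has been measured and on what is new or still open speak of the compounds shown alone.

Compound 1 `CC[C@@H](CCn1cncn1)c1ccc(C)cc1`: 69.9 ug/mL
Compound 2 `CCCC[C@@H](CCn1cncn1)c1ccc(OC)cc1`: 31.6 ug/mL
Compound 3 `CCCC[C@H](CCn1cncn1)c1ccc(C)cc1`: 23.7 ug/mL

In an ADME assay on HEp-2 cells (Homo sapiens) for cytotoxicity, read by MTT assay, with a stated time of 3 days (a higher number here means that more compound is tolerated, a lower number that less compound is tolerated), compound 3 gives the lowest of the three numbers. Compound 2 stands within the usual scatter of compound 3, so the two cannot be told apart on these numbers. Compound 1 stands beyond the scatter, so more of compound 1 is tolerated than of compound 3. For the measured compounds named here, compound 4 `CCCC[C@@H](CCn1cncn1)c1ccc(C)cc1` has not yet been measured in this assay. the two compounds have the same atoms and bonds and differ only in configuration as drawn: 1 of 1 stereo elements differ; a stereocentre at a saturated chain carbon is drawn R in compound 3 and S in compound 4 No measured pair here differs only in this way, so nothing shows how large such a step is. The step from compound 3 to compound 4 is expected to be small, a 1.1-fold higher number from compound 3 to compound 4 (0.02 log units; within the scatter), with no direction beyond the scatter. Compound 4 is therefore expected to give about 25 ug/mL in this assay, between 12 ug/mL and 50 ug/mL.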

Compound 4, half-maximal cytotoxic concentration: 60.7 ug/mL
For compound 4 the middle estimate is 2.4-fold (0.39 log units) below the measured one; the measured number lies above the stated range.
By their numbers in this assay, from the lowest: compounds 3, 2, 4 and 1 (each within the scatter of the next, the first and the last beyond it).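

At the chain carbon, the mirror-image change alone moves the number in this assay, with a 2.6-fold higher number from compound 3 to compound 4 (0.41 log units; beyond the scatter), and nothing else in the structure changes: the fact that compounds 3 and 4 differ only in the configuration as drawn

The other two steps stay within the scatter: a 1.9-fold higher number from compound 2 to compound 4 (0.28 log units; within the scatter) for methyl in place of methoxy, and a 1.2-fold lower number from compound 1 to compound 4 (0.06 log units; within the scatter) for ethyl in place of hydrogen on a saturated chain carbon. Of these three steps, only the mirror-image change can be told apart from the scatter.

Going by these compounds, what the mirror-image forms of compound 1 and compound 2 would give stays open. So does whether an amine or a carboxylic acid in place of the methyl would preserve this difference between mirror images.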